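The compounds below may be only part of what the source reports. "The series", "measured", "known", "first", "only" and "open" are said of these compounds alone.

Of the compounds shown here, three of one series have been tested in a functional assay on PC-3 cells (Homo sapiens) for cytotoxicity, read by MTT assay, with a stated time of 72 h; a higher number here means a weaker inhibitor, a lower number a stronger inhibitor. Compound 1 `N=C(Nc1cccc(C(F)(F)F)c1)c1cc2c(-c3ccccc3)n[nH]c2cn1` gives 19900 nM in this assay. Compound 2 `CN1CCN(c2ccc(NC(=N)c3cc4cn(C)nc4cn3)cc2)CC1` gives 24800 nM, and compound 3 `CN1CCN(c2ccc(NC(=N)c3cc4cnn(C)c4cn3)cc2)CC1` gives 32300 nM. Of the three numbers, that of compound 1 is the smallest, yet its gaps to compound 2 and to compound 3 both stay within the scatter of repeated measurements, so the three compounds cannot be told apart in this assay.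

Compound 4 `Cn1nc(-c2ccccc2)c2cc(C(=N)Nc3cccc(C(F)(F)F)c3)ncc21` has not yet been measured. It differs from compound 1 in one place: methyl in place of hydrogen on an aromatic nitrogen of the shared core. For the measured compounds named here, no pair of measured compounds shows what such a change does in this assay, so there is no measured step to lean on. With compound 1 giving 19900 nM and a change this small, the expectation is a step from compound 1 to compound 4 of a 1.1-fold higher number from compound 1 to compound 4 (0.04 log units; within the scatter), which does not reach beyond the scatter. Compound 4 is therefore estimated at 22000 nM, with a range from 8000 nM to 60000 nM.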

Compound 4, half-maximal inhibitory concentration: 20900 nM
For compound 4 the middle estimate is 1.1-fold (0.02 log units) above the measured one; measured number inside the range.
By their numbers in this assay, from the lowest: compounds 1, 4, 2 and 3 (each within the scatter of the next).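

For the compounds shown here, this is the first measured step: in this assay, methyl in place of hydrogen on an aromatic nitrogen gives a 1.1-fold higher number from compound 1 to compound 4 (0.02 log units; within the scatter). The hydrogen on this nitrogen of the five-membered aromatic ring can therefore be replaced by methyl, one added carbon, without a difference that can be told from repeated measurement. Nothing measured here offers an explanation for this match between the two compounds.

Open, from the compounds shown here alone, is whether a larger group on this nitrogen, such as a longer chain or a chain ending in an amine, would also stay within the scatter. Also open, going by these compounds, is whether the methyl step would stay this small with a carboxylic acid in place of the phenyl group two ring bonds away.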